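This account rests on a few compounds, and the source may have more. Where it says the series, first, only, none or still open, it means among the compounds named here.

In this assay (an assay on HeLa cells for binding affinity to 5-hydroxytryptamine receptor 6 (Homo sapiens); on this read-out higher numbers stand for weaker inhibition and lower numbers for stronger inhibition) the two measured compounds stand as follows:
compound 1, `O=S(=O)(c1ccccc1Cl)n1cc(C2=CCNCC2)c2ccccc21`: 0.4 nM
compound 2, `O=S(=O)(c1ccccc1F)n1cc(C2=CCNCC2)c2ccccc21`: 1 nM

Going by the values given here, compound 2 has the higher of the two numbers; its nearest neighbour is compound 1, and the single step between them, a 2.5-fold higher number from compound 1 to compound 2 (0.40 log units; beyond the scatter), fluoro in place of chloro on an aromatic carbon, is the only measured step. Compound 3, `COc1ccc(S(=O)(=O)n2cc(C3=CCNCC3)c3ccccc32)cc1`, differs from compound 2 in 4-methoxyphenyl in place of 2-fluorophenyl on a sulfonyl sulfur. The step from compound 1 to compound 2 is a halogen exchange on the same phenyl ring and modest; the change to compound 3 replaces the whole substituted phenyl, for which nothing measured gives direct guidance. Since even the small exchange from compound 1 to compound 2 moved the number beyond the scatter, a shift of at least that size, more likely upward, is expected: a 3.0-fold higher number from compound 2 to compound 3 (0.48 log units; beyond the scatter). Compound 3 is expected at 3 nM, range 0.7 nM to 15 nM.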

Compound 3, inhibition constant: 18 nM
For compound 3 the middle estimate is 6.0-fold (0.78 log units) below the measured one, and the stated range ends below it.
By their numbers in this assay, from the lowest: compound 1; then compound 2; then compound 3.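

Notes on the group on the sulfonyl sulfur: in this assay, 4-methoxyphenyl in place of 2-fluorophenyl gives a large rise (an 18-fold higher number from compound 2 to compound 3 (1.26 log units; beyond the scatter)), and in place of 2-chlorophenyl a larger one (a 45-fold higher number from compound 1 to compound 3 (1.65 log units; beyond the scatter)). The earlier halogen exchange was modest by comparison, so this position responds far more to replacing the whole substituted phenyl than to exchanging one halogen for the other. No measurement at hand accounts for the rise.

The change alters both the substituent and its place on the phenyl ring, and the compounds shown do not separate the two. 2-Methoxyphenyl, 4-fluorophenyl and unsubstituted phenyl on the same sulfur would be needed to tell whether the methoxy group or the ring position carries the loss.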